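The source may report more compounds than this note shows. Statements on the series, on what has been measured and on what is new or still open speak of the compounds shown alone.

Compound 1 `NC(=O)c1nn(C2O[C@H](CO)[C@@H](O)[C@H]2O)cc1[N+](=O)[O-]` in a functional assay on Raji cells (Homo sapiens) (on this read-out higher numbers stand for weaker inhibition and lower numbers for stronger inhibition), gives only a limit, > 1730 uM. Compound 2 `NC(=O)c1nn(C2O[C@H](CO)[C@@H](O)[C@H]2O)cc1Br` in this assay likewise gives only a limit, > 1550 uM. The step that the two limits leave unreadable from compound 1 to compound 2 is therefore unreadable, the two values sitting at the limit of > 1730 uM in this assay, at which 1 of the 2 values shown sits, and (the limit of > 1550 uM in this assay, at which 1 of the 2 values shown sits). Compound 3 `Cc1c([N+](=O)[O-])c(C(N)=O)nn1C1O[C@H](CO)[C@@H](O)[C@H]1O` carries methyl in place of hydrogen on an aromatic carbon. Among the compounds with values here, no measured step bears on this change, and the single step, from compound 1 to compound 2, cannot be sized, so neither direction nor magnitude can be drawn from it. Compound 3 is therefore expected to return a value near the limit as well, estimated at 2000 uM within 500 uM to 8000 uM. The corresponding step that the limit leaves unreadable from compound 1 to compound 3 is expected to lie within the usual scatter.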

Compound 3, concentration for 50% inhibition: > 1650 uM
Compound 3 gave a limit, no number; the forecaster's own chance of this, stated with the estimate: 85%; the middle value lies beyond the limit too.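

In this assay compound 3 gives only a limit, > 1650 uM, so its step from compound 1 cannot be read. The compounds shown leave open whether methyl in place of hydrogen on an aromatic carbon changes inhibition at all.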